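Lengthening a Methyl to a Propyl in Compound 2

This account rests on a few compounds, and the source may have more. Where it says the series, first, only, none or still open, it means among the compounds named here.

Of the compounds shown here, two have so far been tested in a functional assay on NCI-H1975 cells (Homo sapiens) for antiproliferative activity, with a stated time of 72 h; on this read-out lower numbers stand for stronger inhibition of growth and higher numbers for weaker inhibition of growth. There, compound 1 (`CCCNC(=O)c1ccc(CN(C)C(=O)c2cc(Cl)c(O)cc2O)cc1`) gives 20800 nM, while compound 2 (`CNC(=O)c1ccc(CN(C)C(=O)c2cc(C(C)C)c(O)cc2O)cc1`) gives 860 nM. Compound 2 therefore holds the lower number of the two, and the gap between them lies beyond the usual scatter of repeated measurements. These two compounds differ in more than one place, however, so their gap cannot be assigned to any single change.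

Compound 3 (`CCCNC(=O)c1ccc(CN(C)C(=O)c2cc(C(C)C)c(O)cc2O)cc1`) is compound 2 with one alteration: ethyl in place of hydrogen on a saturated chain carbon bound to an amide-type nitrogen. This places ethyl in place of hydrogen on a saturated chain carbon bound to an amide-type nitrogen, so methylcarbamoyl becomes propylcarbamoyl. Among the measured compounds shown here, no measured pair shows this change alone, which leaves its effect without a direct guide. The expectation in this assay is therefore no step beyond the scatter, with neither direction favoured. The estimated change is a 1.1-fold lower number from compound 2 to compound 3 (0.03 log units; within the scatter). For compound 3, the expected value is 800 nM, with an estimated range from 300 nM to 2200 nM.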

Compound 3, concentration for 50% growth inhibition: 420 nM
Compound 3: middle estimate off by 1.9-fold (0.28 log units), on the high side; low and high end bracket the measured number.
By their numbers in this assay, from the lowest: compound 3; then compound 2; then compound 1.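

In this assay, among the compounds shown here, the change from methylcarbamoyl to propylcarbamoyl gives a 2.0-fold lower number from compound 2 to compound 3 (0.31 log units; beyond the scatter), with the isopropyl group held constant, so this is the first direct reading of what the chain on the amide-type nitrogen contributes, and the step is modest but beyond the scatter. For the compounds shown here, compound 3 also supplies the first clean comparison for the other site that varies: with propylcarbamoyl held constant, isopropyl in place of chloro on an aromatic carbon gives a 50-fold lower number from compound 1 to compound 3 (1.69 log units; beyond the scatter), a large step that far exceeds the one from lengthening the chain. These two steps show the size and direction of each change in this single pair of comparisons, but nothing available here gives a measured reason for either of them.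

From the compounds shown here alone, it remains open whether lengthening the chain further, to a butyl or pentyl group, would continue the trend, or whether an amine or a carboxylic acid at the end of the propyl chain would keep it. It is also unknown how a tert-butyl group or a bromo group would compare with isopropyl on that aromatic carbon.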